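A Linker Change on the Shared Core and Its Expected Cost

The compounds below may be only part of what the source reports. "The series", "measured", "known", "first", "only" and "open" are said of these compounds alone.

Compound 3 `CC(C(=O)NCc1ccc(C(F)(F)F)nc1Cc1ccccc1)c1ccc(NS(C)(=O)=O)c(F)c1` gives 141 nM in an assay on CHO cells for antagonist activity at transient receptor potential cation channel subfamily V member 1 (Homo sapiens), read by FLIPR (on this read-out lower numbers stand for stronger inhibition and higher numbers for weaker inhibition), the highest number among the three measured compounds. Compound 1 `Cc1cc(-c2nc(C(F)(F)F)ccc2CNC(=O)C(C)c2ccc(NS(C)(=O)=O)c(F)c2)ccc1F` gives 0.4 nM in this assay, and compound 2 `CC(C(=O)NCc1ccc(C(F)(F)F)nc1-c1ccc(Cl)c(Cl)c1)c1ccc(NS(C)(=O)=O)c(F)c1` gives 0.9 nM. The steps of a 350-fold higher number from compound 1 to compound 3 (2.55 log units; beyond the scatter) and a 160-fold higher number from compound 2 to compound 3 (2.19 log units; beyond the scatter) are both large, whereas the step of a 2.3-fold higher number from compound 1 to compound 2 (0.35 log units; beyond the scatter) is modest, so the kind of group on the aromatic carbon next to the ring nitrogen matters far more here than the substituents on the attached phenyl ring.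

Compound 4 `CC(C(=O)NCc1ccc(C(F)(F)F)nc1C#Cc1ccccc1)c1ccc(NS(C)(=O)=O)c(F)c1` differs from compound 3 in one place: 2-phenylethynyl in place of benzyl on an aromatic carbon. The measured steps that bear on this change are those from compound 1 and compound 2 to compound 3, in which a phenyl ring joined directly to the core was replaced by benzyl and the numbers rose sharply. Among the measured compounds shown here, compound 4 again carries its phenyl ring through a linker rather than directly, so no measured step matches it exactly, but the rigid two-carbon linker is a different arrangement from the single carbon of benzyl. A step toward lower numbers is expected, though not a full return to the level of compound 1. The estimate for compound 4 in this assay is 40 nM, with a range from 4 nM to 400 nM. This expected figure corresponds to a step of a 3.5-fold lower number from compound 3 to compound 4 (0.55 log units; beyond the scatter).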

Compound 4, inhibition constant: 0.8 nM
Beside the measured number, compound 4's estimate is 50-fold (1.70 log units) above it, and the stated range ends above it.
By their numbers in this assay, from the lowest: compounds 1, 4 and 2 (each within the scatter of the next, the first and the last beyond it); then compound 3.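

In this assay, the step (a 180-fold lower number from compound 3 to compound 4 (2.25 log units; beyond the scatter)) shows that placing a linker between the shared core and the phenyl ring does not by itself carry a large cost at this position next to the ring nitrogen, for the 2-phenylethynyl group departs sharply from benzyl although both hold the ring away from the core. The 2-phenylethynyl group also stands level with the directly attached rings, as both the step (a 1.1-fold lower number from compound 2 to compound 4 (0.05 log units; within the scatter)) and the step (a 2.0-fold higher number from compound 1 to compound 4 (0.30 log units; within the scatter)) lie within the scatter, so among these four compounds benzyl alone gives a much higher number. Nothing measured here accounts for the gap between benzyl and 2-phenylethynyl.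

The compounds shown leave open whether the triple bond itself is what counts, a question that 2-phenylethyl and 2-phenylethenyl at the same position would address. They also leave open how phenoxy or anilino, which put an oxygen or a nitrogen in the linker, would compare with benzyl, and whether chloro or methyl groups on the phenyl ring of 2-phenylethynyl would shift the number.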